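A few compounds are considered here, and "the series" means these few. Any claim that something is new, unique, unknown or untested is made for them only; others in the source may bear on it.

Of the compounds shown here, two have so far been measured in an ADME assay on NHDF cells (Homo sapiens) for cytotoxicity, read by MTT assay, with a stated time of 72 h; a lower number here means a stronger inhibitor, a higher number a weaker inhibitor. Compound 1 `COc1cc(/C=C2\CCC/C(=C\c3cccc(OC)c3OC)C2=O)ccc1O` gives 14300 nM in this assay. Compound 2 `COc1ccc(/C=C2\CCC/C(=C\c3ccccc3Br)C2=O)cc1OC` gives 21800 nM, the higher of the two numbers, yet compound 1 lies so close that the gap falls within the scatter and the two cannot be told apart. Compound 3 `COc1ccc(/C=C2\CCC/C(=C\c3ccc(O)c(Cl)c3)C2=O)cc1OC` awaits measurement; it differs from compound 2 by 3-chloro-4-hydroxyphenyl in place of 2-bromophenyl on a double-bonded chain carbon bound to a double-bonded ring carbon. With both known numbers sitting together, no step beyond the scatter is expected from this change. For compound 3 the estimate in this assay is 16000 nM, most likely between 6000 nM and 40000 nM, which would be a step of a 1.4-fold lower number from compound 2 to compound 3 (0.13 log units; within the scatter).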

Compound 3, half-maximal inhibitory concentration: 21900 nM
For compound 3 the middle estimate is 1.4-fold (0.14 log units) below the measured one; measured number inside the range.
By their numbers in this assay, from the lowest: compounds 1, 2 and 3 (each within the scatter of the next).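

In this assay, putting 3-chloro-4-hydroxyphenyl in place of 2-bromophenyl on a double-bonded chain carbon bound to a double-bonded ring carbon gives a 1.0-fold higher number from compound 2 to compound 3 (0.00 log units; within the scatter). Among the compounds shown here, this is the first direct step at this position, since compound 1 and compound 2 differ in more than one place, and it shows that this exchange, which adds a hydrogen-bond donor, does not separate the two numbers. Nothing available explains this result. Open, from the compounds shown here alone, is whether an amine or a carboxylic acid on this phenyl ring, or a longer chain in its place, would shift the number beyond the scatter.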